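The source may hold more compounds than are shown below. What is called first, only, known or untested is meant among the compounds shown, and "the series" means these compounds.

Measured so far in a functional assay on HeLa cells (Homo sapiens) for antiproliferative activity, read by MTT assay, with a stated time of 48 h; a higher number here means a weaker inhibitor, a lower number a stronger inhibitor:
compound 1 `Clc1ccccc1CSc1nnc(-c2cnccn2)n1-c1ccccc1`: > 50000 nM
compound 2 `Clc1cccc(CSc2nnc(-c3cnccn3)n2-c2ccccc2)c1`: 13500 nM
compound 3 `Fc1ccc(CSc2nnc(-c3cnccn3)n2-c2ccccc2)c(F)c1`: 12500 nM

Compound 1 sits at the limit of > 50000 nM in this assay, at which 1 of the 3 values shown sits, and this entry is a limit, not a number. Compound 3 belongs to the pair with real numbers in this assay. That pair shows a 1.1-fold lower number from compound 2 to compound 3 (0.03 log units; within the scatter). Both members stand clear of the limit, with an at least 3.7-fold lower number from compound 1 to compound 2 (0.56 log units; beyond the scatter) and an at least 4.0-fold lower number from compound 1 to compound 3 (0.60 log units; beyond the scatter).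

Compound 4 `Fc1cccc(F)c1CSc1nnc(-c2cnccn2)n1-c1ccccc1` is the next point: 2,6-difluorophenyl in place of 2,4-difluorophenyl on a saturated chain carbon bound to a sulfur. In words, this is 2,6-difluorophenyl in place of 2,4-difluorophenyl on a saturated chain carbon bound to a sulfur.

The steps out of compound 1 show that swapping this aryl group can shift the number beyond the scatter, whereas a 1.1-fold lower number from compound 2 to compound 3 (0.03 log units; within the scatter) shows that a swap can also leave it unchanged. By name, the 2-chlorophenyl group of compound 1 is the nearest comparison for the new group. Compound 3 goes against reading much into that, since it gives 12500 nM. A modest move towards a weaker number is therefore expected, with no change also possible. The expected size is a 1.6-fold higher number from compound 3 to compound 4 (0.20 log units; within the scatter). For compound 4 the estimate is 20000 nM, with an expected range of 9000 nM to 50000 nM.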

Compound 4, half-maximal inhibitory concentration: > 50000 nM
Compound 4: only a limit was reported; the forecaster's own chance of this, stated with the estimate: 25%; middle value at least 2.5-fold (0.39 log units) from the limit.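

2,6-difluorophenyl and 2,4-difluorophenyl hold the same atoms, yet this swap on the saturated chain carbon bound to a sulfur gives an at least 4.0-fold higher number from compound 3 to compound 4 (0.60 log units; beyond the scatter), so the arrangement of the two fluorines alone can shift the result in this assay. The change from the 3-chlorophenyl group also gives a clear shift, an at least 3.7-fold higher number from compound 2 to compound 4 (0.56 log units; beyond the scatter), whereas the earlier swap at this place gave a 1.1-fold lower number from compound 2 to compound 3 (0.03 log units; within the scatter); similar numbers for two aryl groups therefore do not mean that this place tolerates every arrangement. Compound 4 gives a limit, not a number, and the step between it and compound 1 cannot be read, as both sit at the same limit: the limit of > 50000 nM in this assay, at which 2 of the 4 values shown sit.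

The 2-chlorophenyl and 2,6-difluorophenyl groups both sit at the limit, but compound 3, with its 2,4-difluorophenyl group, goes against any rule that a name beginning with a 2 marks a compound at the limit. Still open, as far as these compounds go, is whether phenyl, 4-fluorophenyl or 3,5-difluorophenyl would give a number clear of the limit, and how a longer chain between the sulfur and the aryl group would read.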